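The source may hold more compounds than are shown below. What is called first, only, known or untested is meant among the compounds shown, and "the series" means these compounds.

Measured so far in a functional assay on FM3A cells (Mus musculus) for cytotoxicity; a lower number here means that less compound is needed, a higher number that more compound is needed for the effect:
- compound 1 `CCCCOOC1(OOC)CCCCCCCCCCC1`: 20000 nM
- compound 2 `COOC1(OOCCCc2ccccc2)CCCCCCCCCCC1`: 34000 nM
- compound 3 `COOC1(OOCCCCCCI)CCCCCCCCCCC1`: 86000 nM

Among these three, compound 3 has the highest number, and so needs the most compound for the effect. The account now moves from compound 3 to compound 4 `COOC1(OOCCCCCCOC2CCOCC2)CCCCCCCCCCC1`, which is still unmeasured. The change is (oxan-4-yl)oxy in place of iodo on a saturated chain carbon, six bonds along the chain from an oxygen. In words, (oxan-4-yl)oxy replaces iodo on a saturated chain carbon, six bonds along the chain from an oxygen.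

Among the compounds with values here, no measured step makes this same replacement, so the evidence is indirect. Two steps changing the chain end reach compound 3 and are modest: a 4.3-fold higher number from compound 1 to compound 3 (0.63 log units; beyond the scatter) and a 2.5-fold higher number from compound 2 to compound 3 (0.40 log units; beyond the scatter). The third, a 1.7-fold higher number from compound 1 to compound 2 (0.23 log units; within the scatter), shows that a quite different chain end can leave the number unchanged within the scatter. All three values lie within a narrow span, and compound 3 already sits at its top with 86000 nM. A small move back towards the other two is therefore the likeliest outcome in this assay, probably not beyond the scatter. The expected step is a 1.7-fold lower number from compound 3 to compound 4 (0.24 log units; within the scatter). The estimate for compound 4 is 50000 nM, with an expected range of 20000 nM to 130000 nM.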

Compound 4, half-maximal effective concentration: 7600 nM
For compound 4 the middle estimate is 6.6-fold (0.82 log units) above the measured one; the whole stated range lies above it.
By their numbers in this assay, from the lowest: compound 4; then compounds 1 and 2 (each within the scatter of the next); then compound 3.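

In this assay, within the data shown here, the exchange of iodo for (oxan-4-yl)oxy, on a saturated chain carbon six bonds along the chain from an oxygen, gives an 11-fold lower number from compound 3 to compound 4 (1.05 log units; beyond the scatter) and is the first large step, whereas the earlier changes at this chain end were modest or stayed within the scatter. The drop is more than a return from the high number of the iodo compound, since the same chain end also gives a 4.5-fold lower number from compound 2 to compound 4 (0.65 log units; beyond the scatter) and a 2.6-fold lower number from compound 1 to compound 4 (0.42 log units; beyond the scatter) and each of these steps lies beyond the scatter. A change at this chain end can therefore take the number below the narrow span of the three earlier compounds, not only move it within that span, and compound 4 has the lowest number of the four.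

Which part of the entering group goes with this drop stays open, and nothing shown here offers an explanation for it. Whether a methoxy group, a morpholine ring or an amine on the same chain carbon would give a similar number cannot be told from these four compounds.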